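Adding a Second Methyl to the Chain of Compound 3

The compounds below may be only part of what the source reports. "The series", "measured", "known", "first", "only" and "open" are said of these compounds alone.

Compound 1 `Cc1ccc2nc(N3CCCc4ccc(F)cc4C3)cc(NCCN)c2c1` gives in an ADME assay on HEp-2 cells (Homo sapiens) for cytotoxicity, read by CCK-8 assay, with a stated time of 5 days (a higher number here means that more compound is tolerated, a lower number that less compound is tolerated), only a limit, > 3200 nM.
Compound 2 `CNCCNc1cc(N2CCCc3ccc(F)cc3C2)nc2ccc(C)cc12` gives in this assay 29000 nM.
Compound 3 `Cc1ccc2nc(N3CCCc4ccc(F)cc4C3)cc(NC(C)CN)c2c1` gives in this assay 25000 nM.

Compound 3 stands lowest of the two numbers shown, with compound 2 nearest; the gap a 1.2-fold lower number from compound 2 to compound 3 (0.06 log units; within the scatter) is within the scatter, so the two are not told apart. Compound 1 sits at the limit (the limit of > 3200 nM in this assay, at which 1 of the 3 values shown sits), which leaves both steps a step that the limit leaves unreadable from compound 1 to compound 2 and a step that the limit leaves unreadable from compound 1 to compound 3 unreadable.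

Compound 4 `Cc1ccc2nc(N3CCCc4ccc(F)cc4C3)cc(NC(C)(C)CN)c2c1` differs from compound 3 by methyl in place of hydrogen on a saturated chain carbon bound to a nitrogen on an aromatic ring and two saturated chain carbons. Within the data shown here, the only step that bears on it in kind is the one from compound 1 to compound 3, a methyl entering on the same saturated chain carbon, and that step cannot be read because of the limit (the limit of > 3200 nM in this assay, at which 1 of the 3 values shown sits). The readable step from compound 2 to compound 3 lies within the scatter. Among the measured compounds shown here, no measured step therefore points in any direction, and compound 4 is expected to show a step of no change at the digits printed from compound 3 to compound 4 (within the scatter) that stays within the scatter.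

On that basis compound 4 is estimated at 25000 nM, with a range from 8000 nM to 70000 nM.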

Compound 4, half-maximal cytotoxic concentration: 25000 nM
The estimate for compound 4 equals the measured number at the digits printed, and the stated range covers the measured number.
By their numbers in this assay, from the lowest: compounds 3, 4 and 2 (each within the scatter of the next).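

In this assay, among these compounds, the second methyl on the saturated chain carbon bound to a nitrogen on an aromatic ring and two saturated chain carbons gives no change at the digits printed from compound 3 to compound 4 (within the scatter), which makes this the first readable step for a methyl entering on this carbon. Setting 1-(aminomethyl)-1-methylethyl in place of 2-(methylamino)ethyl on the nitrogen on the aromatic ring gives a 1.2-fold lower number from compound 2 to compound 4 (0.06 log units; within the scatter), so compounds 2, 3 and 4 are not told apart in this assay. The step from compound 1 to compound 4 cannot be read, any more than the earlier steps from compound 1, because compound 1 gives only a limit: the limit of > 3200 nM in this assay, at which 1 of the 4 values shown sits.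

The compounds shown leave open how the unbranched 2-aminoethyl chain of compound 1 compares numerically with the branched chains. They also leave open whether an ethyl on this carbon, or a longer chain in place of 1-(aminomethyl)-1-methylethyl, would give a number beyond the scatter of those of compound 3 and compound 4.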